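The source may hold more compounds than are shown below. What is called first, only, known or untested is meant among the compounds shown, and "the series" means these compounds.

Measured compounds in an ADME assay on MT2 cells (Homo sapiens) for cytotoxicity; on this read-out higher numbers stand for lower toxicity in this test and lower numbers for higher toxicity in this test:
- compound 1 `CC1(C)OC(=O)C2(C(=O)O1)[C@@H](c1ccco1)CC(=O)C[C@H]2c1c[nH]c2ccccc12`: > 111000 nM, a limit of the assay
- compound 2 `COc1ccc([C@@H]2CC(=O)C[C@H](c3ccco3)C23C(=O)OC(C)(C)OC3=O)cc1`: > 111000 nM, a limit of the assay
- compound 3 `CC1(C)OC(=O)C2(C(=O)O1)[C@@H](c1ccco1)CC(=O)C[C@H]2c1ccc(F)cc1`: > 111000 nM, a limit of the assay

Compound 3 stands at the limit of this assay, and no number distinguishes it from the other two. All three values shown sit at the limit of > 111000 nM in this assay, at which 3 of the 3 values shown sit, so nothing within the series separates any member from another.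

The three steps between measured compounds are a step that the two limits leave unreadable from compound 1 to compound 2, a step that the two limits leave unreadable from compound 1 to compound 3 and a step that the two limits leave unreadable from compound 2 to compound 3. Going by the values given here, each of them joins two limits and none yields a readable size, so no step in this assay is known in either direction.

Compound 4 `CC1(C)OC(=O)C2(C(=O)O1)[C@@H](c1ccco1)CC(=O)C[C@H]2c1ccc(Br)cc1` is yet to be measured. It differs from compound 3 by bromo in place of fluoro on an aromatic carbon. Among the compounds with values here, the step that bears most directly on this change is the one from compound 2 to compound 3, a change at the same aromatic carbon, and that step is unreadable. Within the data shown here, no measured step therefore gives a size to carry forward, and the only guidance is that every measured member sits at the limit. The step that the limit leaves unreadable from compound 3 to compound 4 is expected to be small, with compound 4 remaining near the limit.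

Compound 4 is expected to give 150000 nM in this assay, within 60000 nM to 400000 nM, most likely reported again only as a limit.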

Compound 4, half-maximal cytotoxic concentration: > 111000 nM
Compound 4 gave a limit, no number (the forecaster's own chance of this, stated with the estimate: 80%); the middle value lies beyond the limit too.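

In this assay compound 4 gives > 111000 nM, a limit of the assay. Its steps from compound 1, compound 2 and compound 3 each join two limits, so none can be read. The compounds shown leave open whether any change on the shared core would give a readable value, as the whole series sits at one limit: the limit of > 111000 nM in this assay, at which 4 of the 4 values shown sit.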